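One Exchange Applied Twice in a Cell Growth Assay

This account rests on a few compounds, and the source may have more. Where it says the series, first, only, none or still open, it means among the compounds named here.

Three measured compounds:
Compound 1 `CC(=O)Oc1ccc(C(=O)Nc2cc3ccc(Oc4ccc(C(C)(C)C)cc4)c(C)c3oc2=O)cc1CC=C(C)C` gives 75000 nM in a functional assay on MCF7 cells (Homo sapiens) for antiproliferative activity; on this read-out higher numbers stand for weaker inhibition and lower numbers for stronger inhibition.
Compound 2 `COc1cccc(-c2cc(C(=O)Nc3cc4ccc(Oc5ccc(C(C)(C)C)cc5)c(C)c4oc3=O)ccc2OC)c1` reaches only the limit of this assay, reported as > 100000 nM.
Compound 3 `COc1ccc(Nc2ccc3cc(NC(=O)c4ccc(OC(C)=O)c(CC=C(C)C)c4)c(=O)oc3c2C)cc1` likewise reaches only the limit of this assay, reported as > 100000 nM.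

Compound 1 and compound 3 share a core and differ in one place: (4-methoxyphenyl)amino in place of 4-(tert-butyl)phenoxy on an aromatic carbon. This exchange gives an at least 1.3-fold higher number from compound 1 to compound 3 (0.12 log units; that floor lies within the scatter), a step whose floor is set by the limit and so lies within the usual scatter of repeated measurements. The difference between the core of compound 1 and the core of compound 2 is not broken down here.

Compound 4 `COc1ccc(Nc2ccc3cc(NC(=O)c4ccc(OC)c(-c5cccc(OC)c5)c4)c(=O)oc3c2C)cc1` has not yet been measured. It stands to compound 2 as compound 3 stands to compound 1: (4-methoxyphenyl)amino in place of 4-(tert-butyl)phenoxy on an aromatic carbon. The surroundings of the exchanged group are described in the same words for both pairs, so this is the same change, made a second time.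

The expectation for compound 4 rests on two things. For the measured compounds named here, compound 2 already sits at the limit (the limit of > 100000 nM in this assay, at which 2 of the 3 values shown sit), and the one measured instance of this exchange also ended at the limit, as an at least 1.3-fold higher number from compound 1 to compound 3 (0.12 log units; that floor lies within the scatter) shows. Compound 4 is therefore expected to give 150000 nM, most likely reported once more as a limit rather than a number. The estimated range for compound 4 runs from 70000 nM to 400000 nM. The step from compound 2 to compound 4 is expected to be a step that the limit leaves unreadable from compound 2 to compound 4.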

Compound 4, half-maximal inhibitory concentration: > 100000 nM
Compound 4 gave a limit, no number; the forecaster's own chance of this, stated with the estimate: 80%; the middle value does not contradict the limit.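

Compound 4 reaches the limit of this assay as well, reported as > 100000 nM and so a limit, not a number. For the compounds shown here, compound 2 carries a limit too, so no step from compound 2 to compound 4 can be read: the limit of > 100000 nM in this assay, at which 3 of the 4 values shown sit. The compounds shown leave open how much (4-methoxyphenyl)amino in place of 4-(tert-butyl)phenoxy changes the read-out in this pair, if it changes it at all.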